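Compound 3 to compound 4: 4-methoxyphenyl to 4-cyanophenyl

This account rests on a few compounds, and the source may have more. Where it says the series, first, only, none or still open, it means among the compounds named here.

In a functional assay on MCF7 cells (Homo sapiens) for antiproliferative activity, with a stated time of 96 h (a lower number here means a stronger inhibitor, a higher number a weaker inhibitor), compound 3 `COc1ccc(C(=O)COc2ccc3c(C(F)(F)F)cc(=O)oc3c2)cc1` carries no number and is recorded as "not active" (no number reported). Compound 2 `O=C(COc1ccc2c(C(F)(F)F)cc(=O)oc2c1)c1ccccc1` is likewise recorded as "not active" (no number reported) in this assay. Compound 1 `Cc1cc(=O)oc2cc(OCC(=O)c3ccc(C#N)cc3)ccc12` gives > 100000 nM in this assay, and this is a limit, not a number. Compound 3 therefore stands among three compounds without a measured potency, and no step can be read from them.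

Compound 4 `N#Cc1ccc(C(=O)COc2ccc3c(C(F)(F)F)cc(=O)oc3c2)cc1` is the unmeasured member. The change is cyano in place of methoxy on an aromatic carbon, with cyano in place of methoxy on an aromatic carbon, para to a large group. In this assay the expected step is none beyond the scatter, or at best a modest one toward stronger inhibition, and the reading may well stay at the limit. This expectation rests on compound 1, which also carries the 4-cyanophenyl and whose value of > 100000 nM is a limit. For compound 4 the estimated value is 60000 nM, with an expected range from 10000 nM to 150000 nM.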

Compound 4, half-maximal inhibitory concentration: "not active" (no number reported)
The entry for compound 4 holds no number; there is nothing to compare the estimate with.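

No step can be read from compound 3 to compound 4: both are recorded as "not active" in this assay, with no number. The compounds shown leave open whether any member of this series gives a measurable potency, and the only printed figure is a limit: the limit of > 100000 nM in this assay, at which 1 of the 4 values shown sits.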